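This account rests on a few compounds, and the source may have more. Where it says the series, first, only, none or still open, it means among the compounds named here.

In an ADME assay on the whole organism (Mus musculus, strain CD-1) for pharmacokinetics, at a dose of 10 mg/kg by the oral route (a higher number here means that a larger share of the oral dose reaches the circulation, a lower number that a smaller share of the oral dose reaches the circulation), compound 1 (`CCOc1cc([C@](O)(CCN(C)C)[C@@H](c2cc3cc(Br)ccc3nc2OC)c2ccnc(OC)c2OC)cc(OC)n1`) gives 70% and compound 2 (`CCCOc1cc([C@](O)(CCN(C)C)[C@@H](c2cc3cc(Br)ccc3nc2OC)c2ccnc(OC)c2OC)cc(OC)n1`) gives 50% while compound 3 (`COc1cc([C@](O)(CCN(C)C)[C@@H](c2cc3cc(Br)ccc3nc2OC)c2ccnc(OC)c2OC)cc(OC2CCC2)n1`) gives 56% on the same core. Compound 3 thus stands level with compound 2 within the scatter (a number 6 percentage points higher from compound 2 to compound 3 (within the scatter)), and its gap to compound 1 lies beyond it (a number 14 percentage points lower from compound 1 to compound 3 (beyond the scatter)). Compound 4 (`COc1cc([C@](O)(CCN(C)C)[C@@H](c2cc3cc(Br)ccc3nc2OC)c2ccnc(OC)c2OC)cc(OC(F)F)n1`) carries difluoromethyl in place of cyclobutyl on an oxygen on an aromatic ring. These steps, with the modest one between the first two compounds (a number 20 percentage points lower from compound 1 to compound 2 (beyond the scatter)), all alter the group on that oxygen. None brings in difluoromethyl, so the data fix no direction, and no step beyond the scatter is expected in this assay here. The expected step is small (a number 2 percentage points higher from compound 3 to compound 4 (within the scatter)). Compound 4 is estimated at 58% with an expected range from 38% to 76%.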

Compound 4, oral bioavailability: 50%
Estimate against measurement, compound 4: 8 percentage points above; low and high end bracket the measured number.
By their numbers in this assay, from the lowest: compounds 2, 4 and 3 (each within the scatter of the next); then compound 1.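

In this assay, difluoromethyl on this oxygen stands level with cyclobutyl (a number 6 percentage points lower from compound 3 to compound 4 (within the scatter)) and with propyl (no change at the digits printed from compound 2 to compound 4 (within the scatter)), while the gap to ethyl remains (a number 20 percentage points lower from compound 1 to compound 4 (beyond the scatter)). Ethyl thus stands apart from all three other groups shown, and bringing in fluorine does not close that gap. No measurement offered here explains this result. From the compounds shown here alone, whether methyl, trifluoromethyl or a chain ending in an amine on this oxygen would match compound 1 remains open.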